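A few compounds are considered here, and "the series" means these few. Any claim that something is new, unique, unknown or untested is made for them only; others in the source may bear on it.

Compound 1 `COCOc1ccc(/C=C/C(=O)c2ccc(OC)cc2O)cc1CC=C(C)C` and compound 2 `COc1ccc(C(=O)/C=C/c2ccc(OC)c(CC=C(C)C)c2)c(O)c1` share one core, and compound 3 `COCOc1ccc2c(c1)OC(c1ccc(OCOC)c(CC=C(C)C)c1)CC2=O` carries another; how the two cores differ is not broken down here. In an assay on isolated protein for inhibition of Aromatase (Homo sapiens) (a lower number here means a stronger inhibitor, a higher number a weaker inhibitor), compound 1 gives only a limit, > 261000 nM, and not a number. In this assay compound 2 likewise gives only a limit, > 283000 nM. The change from compound 1 to compound 2 is hydrogen in place of methoxy on a saturated chain carbon bound to an oxygen on an aromatic ring, and the step it made, a step that the two limits leave unreadable from compound 1 to compound 2, cannot be read because the limit of > 261000 nM in this assay, at which 1 of the 3 values shown sits, and the limit of > 283000 nM in this assay, at which 1 of the 3 values shown sits, both sit at a limit of this assay. Compound 3 is the only one of the three with a number in this assay, giving 14000 nM.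

Compound 4 `COCOc1ccc2c(c1)OC(c1ccc(OC)c(CC=C(C)C)c1)CC2=O` is not yet measured. Within the data shown here, it differs from compound 3 by hydrogen in place of methoxy on a saturated chain carbon bound to an oxygen on an aromatic ring, which is the same change as the one from compound 1 to compound 2, at the same place. Among the compounds shown this change occurs twice, and the only measured instance tells nothing of its size. The expectation for compound 4 therefore rests on compound 3 alone, whose value 14000 nM is the single readable anchor, and on the small size of the group that leaves. Compound 4 is expected to show a step of a 1.3-fold higher number from compound 3 to compound 4 (0.11 log units; within the scatter) from compound 3, which is within the usual scatter. Compound 4 is estimated at 18000 nM in this assay, with a range from 5000 nM to 70000 nM.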

Compound 4, half-maximal inhibitory concentration: 7670 nM
Compound 4: the middle estimate sits 2.3-fold (0.37 log units) above what was measured; low and high end bracket the measured number.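

In this assay, the change from methoxymethoxy to methoxy, hydrogen in place of methoxy on a saturated chain carbon bound to an oxygen on an aromatic ring, gives a 1.8-fold lower number from compound 3 to compound 4 (0.26 log units; within the scatter), so on the core of compound 3 the two values stand within the usual scatter of each other. The same change on the other core, the step that links compound 1 and compound 2, cannot be read, since each of these two compounds gives only a limit of the assay and not a number. The series therefore holds a single readable instance of this change: it shows that the change is tolerated on the core of compound 3 without a step beyond the scatter, but it does not show that the change carries over from one core to the other, and no comparison of step sizes between the cores is possible.

From the compounds shown here alone, what a longer chain or an amine at this same place would do to the number in this assay stays open. Also open, going by these compounds, is whether any change on the core of compound 1 would yield a readable value, which is what a real comparison between the two cores would need.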